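This account rests on a few compounds, and the source may have more. Where it says the series, first, only, none or still open, it means among the compounds named here.

Measured compounds:
Compound 1 `Cc1ccc(-c2cc(C)n(S(=O)(=O)Oc3ccccc3)n2)cc1`: 50.7%
Compound 2 `Cc1ccc(-c2cc(C)n(S(=O)(=O)Oc3ccccc3Cl)n2)cc1`: 48.5%

In a functional assay on the whole organism for inhibition, with Mus musculus as the target, in the writhing test, with stated times of 3 days and 20 min, at a dose of 30 mg/kg by the oral route (on this read-out higher numbers stand for more inhibition at the one dose given (going by the name of the read-out) and lower numbers for less inhibition), compound 1 gives 50.7% and compound 2 gives 48.5%; the two cannot be told apart, since a number 2.2 percentage points lower from compound 1 to compound 2 (within the scatter). Compound 3 `Cc1cc(-c2cccc(Cl)c2)nn1S(=O)(=O)Oc1ccccc1` differs from compound 1 by 3-chlorophenyl in place of 4-methylphenyl on an aromatic carbon. Going by the values given here, the only measured step, from compound 1 to compound 2, concerns a chlorine placed on the other aromatic ring of the shared core, the one carried by the sulfonyl oxygen, and it stayed within the scatter. Among the compounds with values here, no measured step swaps a methyl for a chlorine on the ring carried by the five-membered ring, and none moves a group from one position of that ring to another, so the change in compound 3 is not directly tested here. Within the data shown here, the single step available suggests that adding a chlorine did not move this assay much, so for compound 3 the expected step is a number 5.7 percentage points lower from compound 1 to compound 3 (within the scatter), a small change that may lie within the scatter. Compound 3 is therefore estimated at 45%, with a range from 25% to 65%.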

Compound 3, a percentage reported as inhibition, in the whole organism at one dose (the size of the read-out at that dose, not a potency): 18.9%
Compound 3: the middle estimate sits 26.1 percentage points above what was measured; measured number below the stated range.
By their numbers in this assay, from the lowest: compound 3; then compounds 2 and 1 (each within the scatter of the next).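

In this assay, 3-chlorophenyl in place of 4-methylphenyl on the five-membered ring gives a number 31.8 percentage points lower from compound 1 to compound 3 (beyond the scatter). Going by these compounds alone, the one earlier step, a chlorine on the ring carried by the sulfonyl oxygen, gave a number 2.2 percentage points lower from compound 1 to compound 2 (within the scatter), so this aromatic carbon of the five-membered ring is the first place where a change goes beyond the scatter, and a chlorine-bearing ring there can come with much less inhibition at the one dose tested. Nothing at hand accounts for the size of this drop.

The swap changes two things at once, so the compounds shown cannot say whether the drop goes with the methyl leaving, the chlorine entering or the different place of the substituent on the phenyl ring. On these data alone, whether a methoxy group or an amine on that ring would keep the inhibition of compound 1 also stays open.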